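The compounds below may be only part of what the source reports. "The series", "measured", "known", "first", "only" and "open" are said of these compounds alone.

Compound 2 `COc1cc(C(=O)c2sc3ccccc3c2-c2ccc(Cl)cc2)cc(OC)c1OC` stands second highest of the three numbers in a functional assay on A549 cells (Homo sapiens) for antiproliferative activity, read by MTT assay, with a stated time of 72 h (a lower number here means a stronger inhibitor, a higher number a weaker inhibitor), where compound 2 gives 7500 nM. Compound 1 `COc1cc(C(=O)c2sc3ccccc3c2-c2ccc(F)cc2)cc(OC)c1OC` gives 3200 nM and compound 3 `COc1cc(C(=O)c2sc3ccccc3c2-c2ccc(C)cc2)cc(OC)c1OC` gives 7800 nM. For the measured compounds named here, the measured steps are a 2.3-fold higher number from compound 1 to compound 2 (0.37 log units; beyond the scatter), a 2.4-fold higher number from compound 1 to compound 3 (0.39 log units; beyond the scatter) and a 1.0-fold higher number from compound 2 to compound 3 (0.02 log units; within the scatter), each exchanging only the single group carried on the 4-chlorophenyl ring. Compound 4 `COc1ccc(Nc2c(C(=O)c3cc(OC)c(OC)c(OC)c3)sc3ccccc23)cc1` differs from compound 2 by (4-methoxyphenyl)amino in place of 4-chlorophenyl on an aromatic carbon. Going by the values given here, none of the measured steps removes the whole 4-chlorophenyl group or introduces a hydrogen-bond donor, so they give no direct guide; this change is larger than any step seen, and its direction in this assay is not fixed by the data, so a wide range is kept. Compound 4 is estimated at 1500 nM, with a range of 150 nM to 15000 nM, which would mean an expected step of a 5.0-fold lower number from compound 2 to compound 4 (0.70 log units; beyond the scatter).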

Compound 4, half-maximal inhibitory concentration: 9300 nM
Estimate against measurement, compound 4: 6.2-fold (0.79 log units) below; low and high end bracket the measured number.
By their numbers in this assay, from the lowest: compound 1; then compounds 2, 3 and 4 (each within the scatter of the next).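

In this assay, replacing the whole aryl group at this carbon, with a nitrogen-linked ring bringing a hydrogen-bond donor, does not separate the compounds: a 1.2-fold higher number from compound 2 to compound 4 (0.09 log units; within the scatter) and a 1.2-fold higher number from compound 3 to compound 4 (0.08 log units; within the scatter). Only compound 1 stands apart, with a 2.9-fold higher number from compound 1 to compound 4 (0.46 log units; beyond the scatter), so this position accepts (4-methoxyphenyl)amino with no loss beyond the scatter relative to 4-chlorophenyl or 4-methylphenyl. No supporting data explain this result.

From the compounds shown here alone, it remains open how (4-fluorophenyl)amino would compare with compound 1. A plain amine or a morpholine at this carbon also remains untested among the compounds shown.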